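The compounds below may be only part of what the source reports. "The series", "measured", "known", "first", "only" and "open" are said of these compounds alone.

Compound 1 `Nc1nc2ccc(OC(F)(F)C(F)F)cc2s1` and compound 2 `Nc1nc2ccc(OC(F)(F)C(F)(F)F)cc2s1` share one core. In a functional assay on the whole organism with Rattus norvegicus as the target (on this read-out higher numbers stand for an effect only at larger amounts of compound and lower numbers for an effect already at smaller amounts), compound 1 gives 8.5 mg/kg and compound 2 gives 2.5 mg/kg, a step of a 3.4-fold lower number from compound 1 to compound 2 (0.53 log units; beyond the scatter). Compound 3 `CN(C)S(=O)(=O)CCn1c(=N)sc2cc(OC(F)(F)F)ccc21` returns only a limit in this assay, namely > 10 mg/kg, and so stands at the limit of > 10 mg/kg in this assay, at which 1 of the 3 values shown sits. Where compound 3 falls relative to the other two is therefore not known. Compound 4 `CN(C)CCn1c(=N)sc2cc(OC(F)(F)F)ccc21` is reached from compound 3 by dimethylamino in place of dimethylsulfamoyl on a saturated chain carbon, two bonds along the chain from an aromatic nitrogen. Within the data shown here, the only measured step, from compound 1 to compound 2, concerns fluoro in place of hydrogen and does not bear on this exchange, so no direction beyond the scatter is expected. Compound 4 is expected to give 10 mg/kg in this assay, between 3 mg/kg and 30 mg/kg. The expected step is a number no higher from compound 3 to compound 4 (the limit leaves the size open).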

Compound 4, dose for half-maximal effect: 2.3 mg/kg
Compound 4: middle estimate off by 4.3-fold (0.64 log units), on the high side; the measured number lies below the stated range.
By their numbers in this assay, from the lowest: compounds 4 and 2 (each within the scatter of the next); then compound 1. At a limit, above all of these: compound 3.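

The exchange of dimethylsulfamoyl for dimethylamino on a saturated chain carbon, two bonds along the chain from an aromatic nitrogen, changes the result in this assay: an at least 4.3-fold lower number from compound 3 to compound 4 (0.63 log units; beyond the scatter). Before this, a compound carrying a chain at this place had returned only a limit, so this is the first measured number for such a compound. The full size of the step stays open, because compound 3 stands at a limit: the limit of > 10 mg/kg in this assay, at which 1 of the 4 values shown sits.

As far as these compounds go, what a longer chain ending in dimethylamino would give remains open. So does the outcome for a carboxylic acid on the same chain carbon.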